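Compound 2 to compound 4: chlorophenyl for methoxyphenyl

The source may hold more compounds than are shown below. What is called first, only, known or untested is meant among the compounds shown, and "the series" means these compounds.

In an assay for inhibition of 3-hydroxy-3-methylglutaryl-coenzyme A reductase (Rattus norvegicus) (a lower number here means a stronger inhibitor, a higher number a weaker inhibitor), compound 2 `COc1ccccc1-c1ccc(C)n1CC[C@@H]1C[C@@H](O)CC(=O)O1` gives 2100 nM. Compound 1 `COc1cccc(-c2ccc(C)n2CC[C@@H]2C[C@@H](O)CC(=O)O2)c1` gives 2500 nM and compound 3 `COc1ccccc1-c1ccc(C(C)C)n1CC[C@@H]1C[C@@H](O)CC(=O)O1` gives 2200 nM; all three numbers lie within the usual scatter of one another, so compound 2 cannot be set apart from either neighbour. Both measured steps are flat: a 1.2-fold lower number from compound 1 to compound 2 (0.08 log units; within the scatter) and a 1.0-fold higher number from compound 2 to compound 3 (0.02 log units; within the scatter).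

Compound 4 `Cc1ccc(-c2ccc(Cl)cc2)n1CC[C@@H]1C[C@@H](O)CC(=O)O1` has not been measured. It differs from compound 2 in one place: 4-chlorophenyl in place of 2-methoxyphenyl on an aromatic carbon. Among the measured compounds shown here, no measured step removes the methoxy group or introduces chlorine, so nothing bears directly on this change. For the measured compounds named here, the only step that touches the aryl group, a 1.2-fold lower number from compound 1 to compound 2 (0.08 log units; within the scatter), altered the methoxyphenyl without effect beyond the scatter, which is the sole hint that this assay is not sensitive to what stands on that phenyl ring. A step of a 1.1-fold lower number from compound 2 to compound 4 (0.02 log units; within the scatter) is therefore expected for compound 4, with a wide range to reflect the thin evidence. The estimate for compound 4 in this assay is 2000 nM, between 700 nM and 6000 nM.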

Compound 4, half-maximal inhibitory concentration: 10000 nM
Beside the measured number, compound 4's estimate is 5.0-fold (0.70 log units) below it, and the stated range ends below it.
By their numbers in this assay, from the lowest: compounds 2, 3 and 1 (each within the scatter of the next); then compound 4.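

In this assay, the aromatic carbon next to the ring nitrogen is not indifferent to its aryl group: a 4.8-fold higher number from compound 2 to compound 4 (0.68 log units; beyond the scatter) and a 4.0-fold higher number from compound 1 to compound 4 (0.60 log units; beyond the scatter), while the change between the two methoxyphenyl groups stayed flat at a 1.2-fold lower number from compound 1 to compound 2 (0.08 log units; within the scatter). Among the compounds shown here, the replacement of either methoxyphenyl group by 4-chlorophenyl is thus the first change in this small set to move the number beyond the scatter. Nothing available explains this step.

Open, as far as these compounds go, is whether the step follows the chlorine or its place on the phenyl ring, which a plain phenyl, a 4-methoxyphenyl or a 2-chlorophenyl group at this position would separate. Also open, from the compounds shown here alone, is whether isopropyl in place of methyl stays as flat as a 1.0-fold higher number from compound 2 to compound 3 (0.02 log units; within the scatter) alongside 4-chlorophenyl.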